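The source may hold more compounds than are shown below. What is called first, only, known or untested is meant among the compounds shown, and "the series" means these compounds.

For the measured compounds named here, compound 3 `CC1(C)C=C(n2ccccc2=O)c2cc(C(=O)c3ccco3)ccc2O1` gives 5.92 in a functional assay (trachea) with Rattus norvegicus as the target (on this read-out higher numbers stand for higher potency (the scale is a negative logarithm) and lower numbers for lower potency), which places it second highest of the three numbers measured so far, between compound 1 `COc1ccc2c(c1)C(n1ccccc1=O)=CC(C)(C)O2` with 5.99 and compound 2 `CC1(C)C=C(n2ccccc2=O)c2cc(C(=O)c3cccs3)ccc2O1` with 5.84, both within the scatter of it. Compound 4 `CC1(C)C=C(n2ccccc2=O)c2cc(C(=N)NO)ccc2O1` is not yet measured. It differs from compound 3 in one place: a group of 4 heavy atoms (1 carbon, 2 nitrogen, 1 oxygen; no ring) in place of a group of 7 heavy atoms (5 carbon, 2 oxygen; one five-membered aromatic ring with 1 hetero atom), on an aromatic carbon. Going by the values given here, three measured steps bear on this position. The replacement of methoxy gave a number 0.15 log units lower from compound 1 to compound 2 (within the scatter) and a number 0.07 log units lower from compound 1 to compound 3 (within the scatter), and the exchange of the two five-membered rings on the carbonyl gave a number 0.08 log units higher from compound 2 to compound 3 (within the scatter); each of these stayed within the scatter. The group that enters here brings hydrogen-bond donors where none stood before, a kind of change with no precedent among these compounds, so the data offer no direction beyond the earlier indifference of this position. Compound 4 is therefore expected to give 5.8, in the range 5.2 to 6.4. The step expected from this is a number 0.12 log units lower from compound 3 to compound 4 (within the scatter), most likely within the scatter, with the range widened for the untested nature of the group.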

Compound 4, logarithm of the reciprocal of the active concentration, log(1/C): 5.51
Compound 4: middle estimate off by 0.29 log units, on the high side; low and high end bracket the measured number.
By their numbers in this assay, from the lowest: compound 4; then compounds 2, 3 and 1 (each within the scatter of the next).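

In this assay, for the compounds shown here, this aromatic carbon had carried methoxy, (furan-2-yl)carbonyl and (thiophen-2-yl)carbonyl with every step inside the scatter, but the new group gives the first steps beyond it here: a number 0.41 log units lower from compound 3 to compound 4 (beyond the scatter), a number 0.33 log units lower from compound 2 to compound 4 (beyond the scatter) and a number 0.48 log units lower from compound 1 to compound 4 (beyond the scatter). The position is therefore not indifferent to every group, although all three steps are modest and the three earlier compounds stay within the scatter of one another. No accompanying measurement says why the number falls with this change.

The compounds shown leave open whether the lower number goes with the hydrogen-bond donors that enter or with the absence of a ring, as this one change brings both. On these data alone, whether an amine or a carboxylic acid on the same aromatic carbon would give a similar number also stays open.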